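The compounds below may be only part of what the source reports. "The series", "measured", "known", "first", "only" and "open" are said of these compounds alone.

Compound 3 `CC(C)c1onc(-c2c(Cl)cccc2Cl)c1COc1ccc(-c2nc3ccc(C(=O)O)cc3n2C2CCCCCC2)cc1` in an assay on Huh-7 cells for agonist activity at Bile acid receptor (Homo sapiens), read by a luciferase reporter (a higher number here means that more compound is needed for the effect, a lower number that less compound is needed), gives 14.8 nM. Among the three numbers measured, its nearest neighbour is compound 2 `CC(C)c1onc(-c2c(Cl)cccc2Cl)c1COc1ccc(-c2nc3ccc(C(=O)O)cc3n2CC(C)(C)C)cc1`, which in this assay gives 13 nM, and the furthest is compound 1 `CC(C)c1onc(-c2c(Cl)cccc2Cl)c1COc1ccc(-c2nc3cc(C(=O)O)ccc3n2C)cc1`, which gives 25.8 nM; all three lie within the scatter of one another. The step to compound 4 `CC(C)c1onc(-c2c(Cl)cccc2Cl)c1COc1ccc(-c2nc3ccc(C(=O)O)cc3n2CC2CCCCC2)cc1` changes the group on the aromatic nitrogen: cyclohexylmethyl in place of cycloheptyl on an aromatic nitrogen. Within the data shown here, the only measured step at this position, a 1.1-fold higher number from compound 2 to compound 3 (0.06 log units; within the scatter), shows that exchanging one bulky saturated group for another there left the number essentially unchanged. The same is therefore expected here: compound 4 is estimated to give 14 nM, with a range of 6 nM to 35 nM, which corresponds to an expected step of a 1.1-fold lower number from compound 3 to compound 4 (0.02 log units; within the scatter).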

Compound 4, half-maximal effective concentration: 0.52 nM
The estimate for compound 4 lay 27-fold (1.43 log units) above the measured number; the measured number lies below the stated range.
By their numbers in this assay, from the lowest: compound 4; then compounds 2, 3 and 1 (each within the scatter of the next).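

In this assay the group on the aromatic nitrogen proves far from interchangeable: cyclohexylmethyl in place of cycloheptyl gives a 28-fold lower number from compound 3 to compound 4 (1.45 log units; beyond the scatter) even though the two groups have the same heavy-atom count. Cyclohexyl in place of tert-butyl on the saturated chain carbon gives a 25-fold lower number from compound 2 to compound 4 (1.40 log units; beyond the scatter) whereas the earlier exchange of neopentyl for cycloheptyl stayed within the scatter, so this position does respond to the choice of group. Nothing given here accounts for the drop. The compounds shown leave open whether a benzyl group, a cyclopentylmethyl group or a longer chain ending in cyclohexyl would keep so low a number.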